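Iodo to Trifluoromethyl on the Methoxyphenyl Ring

The compounds below may be only part of what the source reports. "The series", "measured", "known", "first", "only" and "open" are said of these compounds alone.

Compound 1, `COc1cc(NC(=O)Nc2cc(Nc3cc(Br)ccc3OC)ncn2)cc(OC)c1`, gives 76.3% in a functional assay on HCC827 cells (Homo sapiens) for inhibition, read by MTT assay, with a stated time of 48 h, tested at 10 uM; on this read-out higher numbers stand for more inhibition at the one concentration tested (going by the name of the read-out) and lower numbers for less inhibition.
Compound 2, `COc1ccc(C(F)(F)F)cc1Nc1cc(NC(=O)Nc2c(Cl)cccc2Cl)ncn1`, gives 68.7%.
Compound 3, `COc1cc(NC(=O)Nc2cc(Nc3cc(I)ccc3OC)ncn2)cc(OC)c1`, gives 71%.

The three numbers lie close together. Compound 3 sits between the two others, and both gaps are within the scatter: the nearest neighbour is compound 2, the furthest compound 1, so no real ordering among them can be claimed.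

Compound 4, `COc1cc(NC(=O)Nc2cc(Nc3cc(C(F)(F)F)ccc3OC)ncn2)cc(OC)c1`, has not yet been measured. It differs from compound 3 in one place: trifluoromethyl in place of iodo on an aromatic carbon. Among the compounds with values here, only one measured step touches the same position, the exchange of one halogen for another, a number 5.3 percentage points lower from compound 1 to compound 3 (within the scatter), which stayed within the scatter. Compound 2 also carries a trifluoromethyl group, though it differs from compound 3 in other places as well, and its number is within the scatter of compound 3's. Nothing measured here points to a large move in either direction. The expected step is therefore a number 1 percentage points lower from compound 3 to compound 4 (within the scatter), none beyond the scatter. Compound 4 is estimated at 70%, with a range from 58% to 82%.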

Compound 4, a percentage reported as inhibition, at one concentration (the size of the read-out at that concentration, not a potency): 59.7%
Estimate against measurement, compound 4: 10.3 percentage points above; the measured number falls inside the stated range.
By their numbers in this assay, from the lowest: compounds 4, 2, 3 and 1 (each within the scatter of the next, the first and the last beyond it).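

Trifluoromethyl is the first change at this position, para to a methoxy group, to take the number beyond the usual scatter in this assay: the result is a number 11.3 percentage points lower from compound 3 to compound 4 (beyond the scatter), and measured against the bromo compound it is a number 16.6 percentage points lower from compound 1 to compound 4 (beyond the scatter). Both steps are modest, yet they show that this position is not indifferent to what it carries, which the exchange of bromo for iodo alone could not show. At the other end of the molecule, 3,5-dimethoxyphenyl in place of 2,6-dichlorophenyl on an amide-type nitrogen gives a number 9 percentage points lower from compound 2 to compound 4 (within the scatter), so that exchange cannot be told apart from repeat-to-repeat variation when the trifluoromethyl group is held fixed, and nothing available here accounts for the lower number at the trifluoromethyl compound.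

On these data alone, only bromo, iodo and trifluoromethyl are seen at this position, so it remains open how an amine, a methyl group or a carboxylic acid would fare there. As far as these compounds go, it is also open whether bromo or iodo would hold their numbers with 2,6-dichlorophenyl on the amide-type nitrogen.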